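Aryl Substituent Exchange on the Shared Core

The source may report more compounds than this note shows. Statements on the series, on what has been measured and on what is new or still open speak of the compounds shown alone.

Among the compounds with values here, compound 1 `CC1(C)[C@H]2CC[C@]1(C)N(Cc1cn(-c3cccc(F)c3)nn1)C(=O)C2` gives 180 nM in a functional assay on A549 cells (Homo sapiens) for inhibition, read by MTT assay, with a stated time of 24 h (a lower number here means a stronger inhibitor, a higher number a weaker inhibitor), and stands level, within the scatter, with compound 2 `COc1ccccc1-n1cc(CN2C(=O)C[C@@H]3CC[C@@]2(C)C3(C)C)nn1`, which gives 350 nM; the single measured step, a 1.9-fold higher number from compound 1 to compound 2 (0.29 log units; within the scatter), changes the aryl group and stays within the scatter. Compound 3 `CC1(C)[C@H]2CC[C@]1(C)N(Cc1cn(-c3cccc(O)c3)nn1)C(=O)C2` carries hydroxy in place of fluoro on an aromatic carbon. Within the data shown here, no measured step exchanges fluoro for hydroxy, so only the aryl swap bears indirectly on it. A step within the scatter is therefore expected in this assay, a 1.4-fold higher number from compound 1 to compound 3 (0.14 log units; within the scatter), without clear direction. Compound 3 is estimated at 250 nM, with a range from 90 nM to 700 nM.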

Compound 3, half-maximal inhibitory concentration: 180 nM
The estimate for compound 3 lay 1.4-fold (0.14 log units) above the measured number; low and high end bracket the measured number.
By their numbers in this assay, from the lowest: compounds 1, 3 and 2 (each within the scatter of the next).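

In this assay, 3-hydroxyphenyl in place of 3-fluorophenyl gives no change at the digits printed from compound 1 to compound 3 (within the scatter), so this position holds hydroxy as well as fluoro with no step beyond the scatter. The exchange of the whole aryl group gives a 1.9-fold lower number from compound 2 to compound 3 (0.29 log units; within the scatter), which also leaves the aryl groups shown unseparated. Nothing at hand explains this flat result. From the compounds shown here alone, whether an amine or a carboxylic acid at this position would move the number beyond the scatter remains open, as does the effect of a longer chain.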